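Chain acid and tetrazole variants on a shared phenol core

A few compounds are considered here, and "the series" means these few. Any claim that something is new, unique, unknown or untested is made for them only; others in the source may bear on it.

Measured in a functional assay on ileum (Cavia porcellus) with cysteinyl leukotriene receptor (Homo sapiens) as the target; on this read-out higher numbers stand for higher potency (the scale is a negative logarithm) and lower numbers for lower potency:
compound 1 `CCCc1c(COc2ccc(C(=O)CCC(=O)O)cc2)ccc(C(C)=O)c1O` gives 6.75
compound 2 `CCCc1c(COc2ccc(C(=O)CCCc3nnn[nH]3)cc2)ccc(C(C)=O)c1O` gives 7.67
compound 3 `CCCc1c(COc2ccc(C(=O)CC(C)(C)CC(=O)O)cc2)ccc(C(C)=O)c1O` gives 7.73

Compound 3 holds the highest number of the three, but compound 2 lies within the scatter of it, so the two cannot be ordered; only compound 1 stands clearly apart. The step in which the carboxy is exchanged for the tetrazole, a number 0.92 log units higher from compound 1 to compound 2 (beyond the scatter), and the step in which the chain is branched, a number 0.98 log units higher from compound 1 to compound 3 (beyond the scatter), are of similar size, while a number 0.06 log units higher from compound 2 to compound 3 (within the scatter) is within the scatter.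

Compound 4 `CCCc1c(COc2ccc(C(=O)CCCCc3nnn[nH]3)cc2)ccc(C(C)=O)c1O` differs from compound 3 by 3-(1H-tetrazol-5-yl)propyl in place of 1-(carboxymethyl)-1-methylethyl on a saturated chain carbon bound to a carbonyl carbon. This returns to the tetrazole of compound 2 with one further chain carbon. Within the data shown here, the only step bearing on it is that compound 2 and compound 3 are within the scatter of each other; no step describes the lengthening of the chain. For this assay a change of no more than the scatter is therefore expected, a number 0.13 log units lower from compound 3 to compound 4 (within the scatter). Compound 4 is estimated at 7.6, in the range 7 to 8.2.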

Compound 4, negative logarithm of the antagonist equilibrium constant: 7.28
The estimate for compound 4 lay 0.32 log units above the measured number; the range from low to high includes it.
By their numbers in this assay, from the lowest: compound 1; then compound 4; then compounds 2 and 3 (each within the scatter of the next).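

In this assay, the tetrazole series now shows a sensitivity to chain length at this position: with 3-(1H-tetrazol-5-yl)propyl, one chain carbon more than in the earlier tetrazole, the number falls (a number 0.39 log units lower from compound 2 to compound 4 (beyond the scatter)). The longer tetrazole chain also separates from the branched acid chain, which the shorter one could not be told from (a number 0.45 log units lower from compound 3 to compound 4 (beyond the scatter)), yet it still keeps a gain over the unbranched acid (a number 0.53 log units higher from compound 1 to compound 4 (beyond the scatter)). No measurement is at hand that accounts for this loss with chain length.

Open, from the compounds shown here alone, is whether a tetrazole on a chain shorter than that of compound 2 would hold the number. Also open, going by these compounds, is what the two methyl groups of compound 3 would do on a tetrazole chain, and how an unbranched carboxylic acid chain of that same length would compare.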